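Trimming a Saturated Ring: From Compound 3 to Compound 4

The source may report more compounds than this note shows. Statements on the series, on what has been measured and on what is new or still open speak of the compounds shown alone.

Of the compounds shown here, three built on one shared core have been tested in an ADME assay for permeability, using PAMPA, with a stated time of 30 min, at pH 7.4; a higher number here means that the compound crosses the layer faster, a lower number that the compound crosses the layer more slowly. Compound 1 `COc1cccc(CNCCCNc2ccnc3cc(Oc4ccc(Cl)cc4)ccc23)c1O` gives 317 10^-6 cm/s. Compound 2 `COc1cccc(CNCCCNc2ccnc3cc(-c4ccccc4)ccc23)c1O` gives 237 10^-6 cm/s. Compound 3 `COc1cccc(CNCCCNc2ccnc3cc(CC4CCCCC4)ccc23)c1O` gives 23 10^-6 cm/s, the lowest of the three numbers: a 14-fold lower number from compound 1 to compound 3 (1.14 log units; beyond the scatter) and a 10-fold lower number from compound 2 to compound 3 (1.01 log units; beyond the scatter), while a 1.3-fold lower number from compound 1 to compound 2 (0.13 log units; within the scatter). The two large steps are the ones in which an aromatic group is exchanged for the cyclohexylmethyl group.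

Compound 4 `COc1cccc(CNCCCNc2ccnc3cc(CC(C)C)ccc23)c1O` keeps a saturated group in that position but makes it smaller: isopropyl in place of cyclohexyl on a saturated chain carbon bound to an aromatic carbon

Among the compounds with values here, no measured step trades one saturated group for a smaller saturated one, so the two large steps leading into compound 3 bear on this change only loosely. They show that moving from an aromatic group to a saturated one shifted the number a long way, but they say nothing about how the size of the saturated group matters. Within the data shown here, with no direct precedent, the change from compound 3 to compound 4 is expected to move the number only modestly, if at all, and the estimated step is a 1.5-fold higher number from compound 3 to compound 4 (0.18 log units; within the scatter). Compound 4 is therefore expected to give 35 10^-6 cm/s, within a range of 12 10^-6 cm/s to 100 10^-6 cm/s.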

Compound 4, apparent permeability: 23 10^-6 cm/s
The estimate for compound 4 lay 1.5-fold (0.18 log units) above the measured number; measured number inside the range.
By their numbers in this assay, from the lowest: compounds 3 and 4 (each within the scatter of the next); then compounds 2 and 1 (each within the scatter of the next).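

In this assay, replacing cyclohexyl with isopropyl on a saturated chain carbon bound to an aromatic carbon removes the ring and takes the group from 6 heavy atoms to 3, yet the number stays put (no change at the digits printed from compound 3 to compound 4 (within the scatter)). Within the data shown here, this is the first view of size within the saturated groups: across this pair, neither the ring nor the three carbons lost from the group changes the reading. The large gap to the aromatic groups also reappears with isobutyl on the aromatic carbon (a 10-fold lower number from compound 2 to compound 4 (1.01 log units; beyond the scatter); a 14-fold lower number from compound 1 to compound 4 (1.14 log units; beyond the scatter)), so among these four compounds the low number is not unique to cyclohexylmethyl, and none goes against that split. Nothing measured here explains why the two saturated groups read alike.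

Compounds 3 and 4 both join the core through a saturated chain carbon, so a benzyl group, which has that carbon but carries a phenyl ring, would help show whether the carbon or the saturated end goes with the low number. Still open too, going by these compounds, is how a lone methyl, a longer straight chain, an amine or a carboxylic acid would read at this position.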